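The source may hold more compounds than are shown below. What is called first, only, known or untested is meant among the compounds shown, and "the series" means these compounds.

Measured in an in vitro assay on SH-EP1 cells for displacement of a labelled ligand from Neuronal acetylcholine receptor; alpha4/beta2 (Homo sapiens); on this read-out higher numbers stand for weaker inhibition and lower numbers for stronger inhibition: compound 1 `COc1cc(C2=CC3CC(C2)CN(C)C3)cnc1Cl` gives 4.4 nM; compound 2 `Clc1ccc(C2=CC3CNCC(C2)C3)cn1` gives 0.4 nM; compound 3 `COc1cc(C2=CC3CNCC(C2)C3)cnc1Cl` gives 0.4 nM.

Among the compounds with values here, compound 3 stands level with compound 2, and the two share the lowest number of the three; the one large step among the measured compounds is an 11-fold lower number from compound 1 to compound 3 (1.04 log units; beyond the scatter), which came with hydrogen in place of methyl on an amine nitrogen in a ring. Compound 4 `COc1cncc(C2=CC3CNCC(C2)C3)c1` differs from compound 3 by hydrogen in place of chloro on an aromatic carbon, on the carbon next to the ring nitrogen and ortho to a methoxy group. Within the data shown here, no measured step removes the chloro, so there is no direct precedent. Among the measured compounds shown here, the only change on the same aromatic ring is no change at the digits printed from compound 2 to compound 3 (within the scatter). A modest rise in number is therefore expected, estimated as a 5.0-fold higher number from compound 3 to compound 4 (0.70 log units; beyond the scatter). Compound 4 is estimated at 2 nM, within 0.5 nM to 8 nM.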

Compound 4, inhibition constant: 0.3 nM
The estimate for compound 4 lay 6.7-fold (0.82 log units) above the measured number; the measured number lies below the stated range.
By their numbers in this assay, from the lowest: compounds 4, 2 and 3 (each within the scatter of the next); then compound 1.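

In this assay, hydrogen in place of chloro on this aromatic carbon, next to the ring nitrogen and ortho to a methoxy group, gives a 1.3-fold lower number from compound 3 to compound 4 (0.12 log units; within the scatter) and so shows that the low number does not depend on the chloro in this compound. No measurement shown gives a reason for this result.

Still open, from the compounds shown here alone, is whether fluoro, an amine or a nitrile on this carbon would keep the number this low. Also open, going by these compounds, is whether hydrogen here would do as well without the methoxy group.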